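Aryl variation at the biaryl position: working notes

The source may report more compounds than this note shows. Statements on the series, on what has been measured and on what is new or still open speak of the compounds shown alone.

Measured so far:
compound 1, `CCN(c1ccc(C#N)c(Cl)c1)c1cc(-c2ccoc2)ccc1C`: > 30000 nM in a functional assay on PC-3 cells (Homo sapiens) for antiproliferative activity, read by CCK-8 assay, with a stated time of 6 days; a lower number here means a stronger inhibitor, a higher number a weaker inhibitor.
compound 2, `CCN(c1ccc(C#N)c(Cl)c1)c1cc(-c2ccccc2)ccc1C`: "not determined" (no result reported) in this assay.

Compound 1 sits at the limit of > 30000 nM in this assay, at which 1 of the 2 values shown sits, a limit and not a number. Compound 2 has no number in this assay, so it stands nowhere on the scale. Compound 3, `CCN(c1ccc(C#N)c(Cl)c1)c1cc(-c2cccnc2)ccc1C`, carries pyridin-3-yl in place of phenyl on an aromatic carbon. Going by the values given here, with no measured step on record, no direction can be read; the step from compound 2 to compound 3 in this assay is expected to stay within the usual scatter. Compound 3 is estimated at 20000 nM, between 4000 nM and 30000 nM, with a real chance of only a limit.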

Compound 3, half-maximal inhibitory concentration: 11000 nM
Compound 3: the middle estimate sits 1.8-fold (0.26 log units) above what was measured; the range from low to high includes it.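

In this assay, this position now yields a measured number rather than only a limit: pyridin-3-yl in place of furan-3-yl on an aromatic carbon gives an at least 2.7-fold lower number from compound 1 to compound 3 (0.43 log units; beyond the scatter). The true size of this step remains unknown, because the value for compound 1 is a limit and not a number: the limit of > 30000 nM in this assay, at which 1 of the 3 values shown sits.

On these data alone, compound 2 has no number, so the steps from compound 2 to the other two compounds cannot be read, and the effect of the ring nitrogen relative to phenyl stays open. Also open, as far as these compounds go, is how an amine or a carboxylic acid on the aryl ring would read at this position.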